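A few compounds are considered here, and "the series" means these few. Any claim that something is new, unique, unknown or untested is made for them only; others in the source may bear on it.

Compound 1 `C[C@]1(C(=O)O)CC[C@H](C(=O)N2CC[C@](c3ccc(C(F)(C(F)(F)F)C(F)(F)F)cc3)(S(=O)(=O)c3ccc(F)cc3)C2)CC1` gives 93% in an ADME assay on microsomes from liver (Mus musculus) for metabolic stability, with a stated time of 10 min; on this read-out lower numbers stand for a less stable compound and higher numbers for a more stable compound.
Compound 2 `C[C@]1(C(=O)N2CC[C@](c3ccc(C(F)(C(F)(F)F)C(F)(F)F)cc3)(S(=O)(=O)c3ccc(F)cc3)C2)CC[C@H](C(=O)O)CC1` gives 95% in this assay.
Compound 3 `CO[C@]1(C(=O)N2CC[C@](c3ccc(C(F)(C(F)(F)F)C(F)(F)F)cc3)(S(=O)(=O)c3ccc(F)cc3)C2)CC[C@H](C(=O)O)CC1` gives 95% in this assay.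

Compound 3 stands level with compound 2 at the digits shown, and the two together hold the highest numbers of the three; its nearest neighbour is compound 2, with no change at the digits printed from compound 2 to compound 3 (within the scatter), and its furthest is compound 1, with a number 2 percentage points higher from compound 1 to compound 3 (within the scatter). All three measured compounds share one core and differ only on the ring that carries the carboxylic acid.

Compound 4 `O=C(N1CC[C@](c2ccc(C(F)(C(F)(F)F)C(F)(F)F)cc2)(S(=O)(=O)c2ccc(F)cc2)C1)C1(F)CCS(=O)(=O)CC1` is the unmeasured member. Relative to compound 3 the change is 4-fluoro-1,1-dioxothian-4-yl in place of 4-carboxy-1-methoxycyclohexyl on a carbonyl carbon. The measured steps all concern this same ring: a number 2 percentage points higher from compound 1 to compound 2 (within the scatter), a number 2 percentage points higher from compound 1 to compound 3 (within the scatter) and no change at the digits printed from compound 2 to compound 3 (within the scatter), each within the scatter. None of them, however, removes the carboxylic acid or exchanges the carbon ring for one with a hetero atom, so they bear on the new step only in showing that the core has so far kept its high reading whatever stood on that ring. On this basis no change beyond the scatter is expected in this assay, with the range widened to allow for the untested nature of the change. Compound 4 is therefore estimated at 88%, between 60% and 99%, which means an expected step of a number 7 percentage points lower from compound 3 to compound 4 (within the scatter).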

Compound 4, percent of the compound remaining: 90%
Compound 4: middle estimate off by 2 percentage points, on the low side; the range from low to high includes it.
By their numbers in this assay, from the lowest: compounds 4, 1, 2 and 3 (each within the scatter of the next).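

In this assay, the reading on the shared core holds within the scatter when 4-fluoro-1,1-dioxothian-4-yl stands on the carbonyl carbon whose other neighbours are an amide-type nitrogen in a ring, with a number 5 percentage points lower from compound 3 to compound 4 (within the scatter) and a number 5 percentage points lower from compound 2 to compound 4 (within the scatter) and also a number 3 percentage points lower from compound 1 to compound 4 (within the scatter) as the three steps. Among the compounds shown here, the earlier compounds all kept a carboxylic acid on a ring of carbon only, so compound 4 is the first of the set to show that, at this position, neither that acid nor the all-carbon ring is required for a high reading in this assay, although this rests on a single compound. No measurement bears on why the reading holds across this change.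

The new group differs from the old ones in several ways at once, as it brings a fluorine and a ring sulfone while losing the carboxylic acid and the methoxy or methyl group, so the share of each part stays unresolved. Also open, as far as these compounds go, is whether an amine or a hydroxyl in place of the fluorine, or a carboxylic acid carried on the 1,1-dioxothiane ring, would leave the reading in this assay where it stands.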